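Small Amide Substituent Change on a Thioether Quinazoline-Type Core

This account rests on a few compounds, and the source may have more. Where it says the series, first, only, none or still open, it means among the compounds named here.

Compound 2 `CC(C)c1ccc2c(Nc3cc(C(=O)N[C@@](C)(CO)c4ccccc4)ccc3Sc3ccc(N)cc3)ncnc2n1` gives 1.1 h in an ADME assay on the whole organism (strain Sprague-Dawley) for metabolic stability, with Rattus norvegicus as the target, at a dose of 5 mg/kg by the intravenous route (a higher number here means that the compound lasts longer, a lower number that the compound disappears faster), which places it second highest of the three numbers available. Compound 1 `CC(C)c1ccc2c(Nc3cc(C(=O)N[C@@H](C)c4ccccc4)ccc3Sc3ccc(N)cc3)ncnc2n1` gives 1.6 h, and compound 3 `COC(=O)Nc1ccc(Sc2ccc(C(=O)N[C@@H](C)c3ccccc3)cc2Nc2ncnc3nc(C(C)C)ccc23)cc1` gives 0.4 h. The step of a 1.5-fold lower number from compound 1 to compound 2 (0.16 log units; within the scatter) lies within the scatter, while a 4.0-fold lower number from compound 1 to compound 3 (0.60 log units; beyond the scatter) reaches beyond it.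

Compound 4 `Cc1ccc([C@H](C)NC(=O)c2ccc(Sc3ccc(N)cc3)c(Nc3ncnc4nc(C(C)C)ccc34)c2)cc1` has not been measured. It differs from compound 2 by 1-(4-methylphenyl)ethyl in place of 1-(hydroxymethyl)-1-phenylethyl on an amide-type nitrogen. Among the compounds with values here, the only measured step that bears on this change is a 1.5-fold lower number from compound 1 to compound 2 (0.16 log units; within the scatter), which concerns the hydroxymethyl group that leaves here and was within the scatter. Within the data shown here, no measured step addresses the methyl group on the aromatic ring that enters, so that part of the change carries no precedent. Taken together, the change from compound 2 to compound 4 is expected to give at most a step within the scatter, a 1.3-fold higher number from compound 2 to compound 4 (0.10 log units; within the scatter). Compound 4 is therefore estimated at 1.4 h in this assay, within a range of 0.6 h to 3.2 h.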

Compound 4, half-life: 0.7 h
For compound 4 the middle estimate is 2.0-fold (0.30 log units) above the measured one; low and high end bracket the measured number.
By their numbers in this assay, from the lowest: compounds 3, 4, 2 and 1 (each within the scatter of the next, the first and the last beyond it).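

In this assay the methyl group on the aromatic ring now has a direct measured step of its own, since adding it alone gives a 2.3-fold lower number from compound 1 to compound 4 (0.36 log units; beyond the scatter) and this step lies beyond the scatter. The full exchange of 1-(hydroxymethyl)-1-phenylethyl for 1-(4-methylphenyl)ethyl on the amide-type nitrogen gives only a 1.6-fold lower number from compound 2 to compound 4 (0.20 log units; within the scatter), so these two substituents cannot be told apart in this measurement, even though they differ in the hydroxymethyl group as well as the methyl group. Nothing available accounts for either step.

On these data alone, it remains open whether a fluorine or a methoxy group in place of that methyl would give a similar step. As far as these compounds go, it also remains open how the number would read with the hydroxymethyl and methyl groups together in one compound.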